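A few compounds are considered here, and "the series" means these few. Any claim that something is new, unique, unknown or untested is made for them only; others in the source may bear on it.

The study sets three measured compounds beside one that is still to be tested, all read in an ADME assay on HEp-2 cells (Homo sapiens) for cytotoxicity, read by CCK-8 assay, with a stated time of 6 days; on this read-out lower numbers stand for higher toxicity in this test and higher numbers for lower toxicity in this test. Compound 1 `O=c1n(Cc2nc3ccc(C(F)(F)F)cn3c2CCCCO)c2cnccc2n1C1CC1` reaches only the limit of the test there: in this assay compound 1 gives > 100000 nM. Compound 2 `CCc1ccn2c(CCCCO)c(Cn3c(=O)n(C4CC4)c4ccncc43)nc2c1` likewise returns only a limit, and in this assay compound 2 gives > 100000 nM. Going by the values given here, compound 3 `O=c1n(Cc2cn3ccc(Cl)cc3n2)c2cnccc2n1C1CC1` is the single compound with an actual number: in this assay compound 3 gives 22300 nM. Compound 3 therefore stands alone as the one measured figure, the other two entries being limits, and what the measured set offers as evidence is the limit of > 100000 nM in this assay, at which 2 of the 3 values shown sit.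

Compound 4 `CS(=O)(=O)NC(=O)CCc1c(Cn2c(=O)n(C3CC3)c3ccncc32)nc2cc(Cl)ccn12` differs from compound 3 in one place: 2-((methylsulfonyl)carbamoyl)ethyl in place of hydrogen on an aromatic carbon. Among the compounds with values here, no step between two measured compounds exists against which this change could be weighed, so the expectation rests on compound 3 alone and on the fact that two of three compounds sit at the limit. The change is estimated to produce a 2.0-fold higher number from compound 3 to compound 4 (0.30 log units; within the scatter), a modest step toward lower toxicity in this assay, though a shift within the scatter would not surprise. Compound 4 is expected to give 45000 nM in this assay, with a range from 15000 nM to 150000 nM, and a fair chance that only a limit is reported.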

Compound 4, half-maximal cytotoxic concentration: > 100000 nM
Compound 4 ended at the assay's limit; the forecaster's own chance of this, stated with the estimate: 40%; middle value at least 2.2-fold (0.34 log units) from the limit.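

Going by these compounds alone, until now no measured step existed at this position. In this assay, 2-((methylsulfonyl)carbamoyl)ethyl in place of hydrogen on an aromatic carbon of the five-membered ring gives an at least 4.4-fold higher number from compound 3 to compound 4 (0.65 log units; beyond the scatter). In this assay compound 4 gives > 100000 nM, which is a limit of the test, so the size of the step is known only as a lower bound. The change therefore carries compound 3, the one compound with an actual number, beyond the scatter toward lower toxicity in this test and to the point where the set now gathers: the limit of > 100000 nM in this assay, at which 3 of the 4 values shown sit.

The compounds shown leave open whether this step belongs to the 2-((methylsulfonyl)carbamoyl)ethyl group as a whole, to its terminal methylsulfonyl part, or to any chain at this carbon. On these data alone, a carboxylic acid at the end of the same chain, a plain propyl chain or an amine at this place would tell these readings apart, and how much of the step lies past the limit stays unknown.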